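This account rests on a few compounds, and the source may have more. Where it says the series, first, only, none or still open, it means among the compounds named here.

Of the compounds shown here, three have been tested in a functional assay on HL-60 cells (Homo sapiens) for inhibition, read by MTT assay, with a stated time of 72 h (on this read-out higher numbers stand for weaker inhibition and lower numbers for stronger inhibition), and they share a core in which an aromatic ring bearing a small chain is joined through a carbonyl to a six-membered ring with two nitrogens, the second nitrogen carrying a substituted phenyl ring.

Compound 1 `CCc1nc(-c2ccc(OC)cc2)c(C(=O)N2CCN(c3cccc(Cl)c3)CC2)o1` gives only a limit in this assay, > 1000 nM, which means no number could be read for it (the limit of > 1000 nM in this assay, at which 1 of the 3 values shown sits).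

Compound 2 `Cc1nc(-c2ccccc2)c(C(=O)N2CCN(c3ccccc3Cl)CC2)o1` gives 124 nM in this assay. Compound 3 `Cc1nc(-c2ccc(F)cc2)c(C(=O)N2CCN(c3cc(Cl)cc(Cl)c3)CC2)o1` gives 52.1 nM in this assay. Of the two numbers that were obtained, compound 2 is the higher one, so on this read-out it is the weaker inhibitor of the pair, and its gap to compound 3 lies beyond the usual scatter.

Compound 4 `Cc1cc(C)cc(N2CCN(C(=O)c3oc(C)nc3-c3ccccc3)CC2)c1` has not yet been measured. It differs from compound 2 in one place: 3,5-dimethylphenyl in place of 2-chlorophenyl on an amine nitrogen in a ring. Among the compounds with values here, no pair of measured compounds differs by exactly this change, so nothing measured fixes its size. Compound 3, whose phenyl ring carries two substituents at the same positions as the methyls of compound 4, gives the lower number of the pair, which leans the expectation slightly toward a lower number, but a step within the scatter is the most likely outcome.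

For compound 4 the expected step of a 1.4-fold lower number from compound 2 to compound 4 (0.14 log units; within the scatter) is small, and the estimate is 90 nM, within a range from 30 nM to 300 nM.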

Compound 4, half-maximal inhibitory concentration: 34.5 nM
Estimate against measurement, compound 4: 2.6-fold (0.42 log units) above; the range from low to high includes it.
By their numbers in this assay, from the lowest: compounds 4 and 3 (each within the scatter of the next); then compound 2. At a limit, above all of these: compound 1.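

In this assay, placing 3,5-dimethylphenyl where 2-chlorophenyl stood on the amine nitrogen in the ring gives a 3.6-fold lower number from compound 2 to compound 4 (0.56 log units; beyond the scatter), a modest step but one that lies beyond the usual scatter. Within the data shown here, this is the first comparison in which only this one group changes, so it shows directly that the aromatic ring on this nitrogen can move the result on its own, and that a ring with no chlorine on it can still give the lower number of such a pair. Nothing measured here explains the step, as the data hold no separate measurement of any property of the two groups, so the change can be recorded only as a change in the number.

The two rings differ in their substituents and in where these sit, so this single step cannot show whether the methyl groups, the loss of the chlorine or the new substitution pattern accounts for it. It also leaves open how the number would respond to a phenyl ring on this nitrogen bearing a methoxy group, an amine or a carboxylic acid, with all else in compound 2 kept the same.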